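A few compounds are considered here, and "the series" means these few. Any claim that something is new, unique, unknown or untested is made for them only; others in the source may bear on it.

Measured compounds:
- compound 1 `Cc1cccc(N2C(=O)CSC2c2cccc(C(=O)NCCCCc3ccccc3)c2)c1`: 2940 mL.min-1.g-1
- compound 2 `Cc1ccnc(N2C(=O)CSC2c2cccc(C(=O)NCCCCn3cccn3)c2)c1`: 392 mL.min-1.g-1
- compound 3 `O=C(NCCCCc1ccccc1)c1cccc(C2SCC(=O)N2c2cccc(F)c2)c1`: 2740 mL.min-1.g-1

In an ADME assay on microsomes from liver (Mus musculus) for metabolic stability, read by LC-MS, using NADPH, with a stated time of 10 min, tested at 0.1 uM (on this read-out higher numbers stand for fast clearance and lower numbers for slow clearance), compound 1 gives 2940 mL.min-1.g-1 and compound 3 gives 2740 mL.min-1.g-1. The step between them is a 1.1-fold lower number from compound 1 to compound 3 (0.03 log units; within the scatter); the change is fluoro in place of methyl on an aromatic carbon, placed on an aromatic carbon of a six-membered aromatic ring of carbon only, meta to a large group. Compound 2 stands apart from both in this assay with 392 mL.min-1.g-1; the difference between the cores of compound 1 and compound 2 is not broken down here.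

Compound 4 `O=C(NCCCCn1cccn1)c1cccc(C2SCC(=O)N2c2cc(F)ccn2)c1` is not yet measured. It differs from compound 2 by fluoro in place of methyl on an aromatic carbon. This is the same kind of change as that from compound 1 to compound 3, but not the same: here the place is an aromatic carbon of a six-membered aromatic ring with 1 nitrogen, meta to a large group and opposite the ring nitrogen, whereas in the earlier pair the ring is of carbon only. Because a 1.1-fold lower number from compound 1 to compound 3 (0.03 log units; within the scatter) lies within the scatter, the expectation for compound 4 in this assay rests on the value of compound 2, 392 mL.min-1.g-1, with little shift. The expected step is a 1.1-fold lower number from compound 2 to compound 4 (0.04 log units; within the scatter). The estimate for compound 4 in this assay is 360 mL.min-1.g-1, between 150 mL.min-1.g-1 and 900 mL.min-1.g-1.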

Compound 4, intrinsic clearance in microsomes in the Mus musculus assay: 397 mL.min-1.g-1
Beside the measured number, compound 4's estimate is 1.1-fold (0.04 log units) below it; the range from low to high includes it.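

In the Mus musculus assay compound 2 gives 392 mL.min-1.g-1 and compound 4 gives 397 mL.min-1.g-1; fluoro in place of methyl on the core of compound 2 gives a 1.0-fold higher number from compound 2 to compound 4 (0.01 log units; within the scatter), and the step agrees with the one seen earlier on the other core: the same change on two cores in the Mus musculus assay, a 1.1-fold lower number (0.03 log units; within the scatter) from compound 1 to compound 3 and a 1.0-fold higher number (0.01 log units; within the scatter) from compound 2 to compound 4, 1.1-fold (0.04 log units) apart, within the scatter of two such steps On these two pairs, the swap therefore carries from a six-membered aromatic ring of carbon only to one with 1 nitrogen without a readable step on either core. In a physicochemical assay for solubility, read by turbidimetry, measured as kinetic solubility, at pH 7.4 (a higher number here means a more soluble compound, a lower number a less soluble compound), compound 2 gives 50000 nM and compound 4 gives 50000 nM, and the same swap gives no change at the digits printed from compound 2 to compound 4 (within the scatter). This supports only a narrow reading: two pairs agree that the step is too small to read, which does not show how a swap with a real step would carry between these cores, and it says nothing about which of the differences between the core of compound 1 and the core of compound 2 matters for clearance.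

Still open, going by these compounds, is whether other groups at this place, such as chloro, methoxy or an amine, would also give no readable step on both cores. Also open, on these data alone, is how the series would read in either assay with a carboxylic acid or a longer chain on the amide side of the molecule.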